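Nitro to fluoro on the aromatic nitrogen substituent

The compounds below may be only part of what the source reports. "The series", "measured", "known", "first", "only" and "open" are said of these compounds alone.

Compound 1 `C/C(=C\CC/C(C)=C/CC[C@@H]1[C@@]2(C)CCC(=O)C(C)(C)[C@H]2CC[C@@]1(C)O)CC/C=C(\C)C(=O)OCc1cn(-c2ccccc2[N+](=O)[O-])nn1` carries 2-nitrophenyl on an aromatic nitrogen. In a functional assay on A549 cells (Homo sapiens) for antiproliferative activity, read by MTT assay, with a stated time of 48 h (on this read-out lower numbers stand for stronger inhibition and higher numbers for weaker inhibition), compound 1 gives only a limit of the assay, > 150000 nM. Compound 2 `C/C(=C\CC/C(C)=C/CC[C@@H]1[C@@]2(C)CCC(=O)C(C)(C)[C@H]2CC[C@@]1(C)O)CC/C=C(\C)C(=O)OCc1cn(-c2cccc(C)c2)nn1` likewise shows a limit in this assay, > 150000 nM. Compound 3 `C/C(=C\CC/C(C)=C/CC[C@@H]1[C@@]2(C)CCC(=O)C(C)(C)[C@H]2CC[C@@]1(C)O)CC/C=C(\C)C(=O)OCc1cn(-c2ccc(C)cc2)nn1` also returns a limit, > 150000 nM. The steps a step that the two limits leave unreadable from compound 1 to compound 2, a step that the two limits leave unreadable from compound 1 to compound 3 and a step that the two limits leave unreadable from compound 2 to compound 3 are of unreadable size, since (the limit of > 150000 nM in this assay, at which 3 of the 3 values shown sit). Compound 4 `C/C(=C\CC/C(C)=C/CC[C@@H]1[C@@]2(C)CCC(=O)C(C)(C)[C@H]2CC[C@@]1(C)O)CC/C=C(\C)C(=O)OCc1cn(-c2ccccc2F)nn1` differs from compound 1 by fluoro in place of nitro on an aromatic carbon. Going by the values given here, no measured step touches this change, and every value shown sits at the limit. Compound 4 is therefore expected to stay near that limit, with an estimated 250000 nM in a range from 120000 nM to 600000 nM. The expected step that the limit leaves unreadable from compound 1 to compound 4 cannot be read against a limit.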

Compound 4, half-maximal inhibitory concentration: > 150000 nM
Compound 4: a limit, no number; the forecaster's own chance of this, stated with the estimate: 85%; the middle value does not contradict the limit.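

Compound 4, like compound 1, compound 2 and compound 3, returns only a limit, so no step among these compounds can be read: the limit of > 150000 nM in this assay, at which 4 of the 4 values shown sit. Going by these compounds, whether any substituent on the aromatic nitrogen brings a measurable value remains open.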